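Chloro substitution on two purine nucleoside cores

The compounds below may be only part of what the source reports. "The series", "measured", "known", "first", "only" and "open" are said of these compounds alone.

compound 1 `CNc1ncnc2c1ncn2[C@@H]1O[C@H]([C@H](O)CO)[C@@H](O)[C@H]1O` — in a functional assay on MCF7 cells (Homo sapiens), read by colorimetric assay, with a stated time of 96 h (on this read-out lower numbers stand for stronger inhibition and higher numbers for weaker inhibition), a limit of the assay, > 100000 nM
compound 2 `CNc1nc(Cl)nc2c1ncn2[C@@H]1O[C@H]([C@H](O)CO)[C@@H](O)[C@H]1O` — in this assay a limit of the assay, > 100000 nM
compound 3 `CC(=O)OC[C@@H](OC(C)=O)[C@H]1O[C@@H](n2cnc3c(Cl)ncnc32)[C@H](OC(C)=O)[C@@H]1OC(C)=O` — in this assay a limit of the assay, > 100000 nM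

Compound 4 `CC(=O)OC[C@@H](OC(C)=O)[C@H]1O[C@@H](n2cnc3c(Cl)nc(Cl)nc32)[C@H](OC(C)=O)[C@@H]1OC(C)=O` has not been measured yet. The change from compound 1 to compound 2 is chloro in place of hydrogen on an aromatic carbon. The change from compound 3 to compound 4 is chloro in place of hydrogen on an aromatic carbon. The two are the same kind of change, not the same: around the place, the first sits meta to a methylamino group (2 heavy atoms), the second meta to a chloro group (1 heavy atom). The difference between the two cores is not broken down here.

The measured step that the two limits leave unreadable from compound 1 to compound 2 gives no readable size, since both ends sit at the limit of > 100000 nM in this assay, at which 3 of the 3 values shown sit. Nothing in the three values separates one compound from another.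

For compound 4 a step that the limit leaves unreadable from compound 3 to compound 4 is expected, resting on the limit of > 100000 nM in this assay, at which 3 of the 3 values shown sit, and on the unreadable a step that the two limits leave unreadable from compound 1 to compound 2. Compound 4 is expected at 150000 nM, with a range from 40000 nM to 600000 nM, and most likely the assay again reports only a limit.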

Compound 4, half-maximal inhibitory concentration: 22400 nM
Estimate against measurement, compound 4: 6.7-fold (0.83 log units) above; measured number outside the range, below it.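

In this assay, chloro in place of hydrogen on an aromatic carbon gives an at least 4.4-fold lower number from compound 3 to compound 4 (0.64 log units; beyond the scatter), so on the core of compound 3 this change lowers the number beyond the scatter. Among these compounds, the same kind of change on the core of compound 1 cannot be read, so this series neither confirms nor refutes that the change carries from one core to the other, and the step on the core of compound 3 is a bound rather than a size, with both readings resting on one end point: the limit of > 100000 nM in this assay, at which 3 of the 4 values shown sit. Compound 4 is the only compound with a number, so the result holds for that core alone and gives no cause for the lower value.

As far as these compounds go, it remains open whether an amine or a bromo group on the same carbon, between two ring nitrogen atoms, would also bring the number under the limit. From the compounds shown here alone, it is equally open whether the acetate esters are needed for the step, or whether the same chloro change would read on a core with free hydroxyl groups.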